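Replacing a Phenol: Expected Microsomal Clearance of Compound 3

A few compounds are considered here, and "the series" means these few. Any claim that something is new, unique, unknown or untested is made for them only; others in the source may bear on it.

Compound 1 `Cc1cc(O)ccc1NC(=O)c1cc(N(CC2CC2)C2CCCCC2)ncn1`: 22 mL.min-1.g-1
Compound 2 `Cc1cc2[nH]ncc2cc1NC(=O)c1cc(N(CC2CC2)C2CCCCC2)ncn1`: < 10 mL.min-1.g-1 (a limit of the assay, not a number)

Within the data shown here, in an in vitro ADME assay on microsomes from liver (Homo sapiens) for metabolic stability, read by LC-MS, tested at 3 uM (on this read-out lower numbers stand for slow clearance and higher numbers for fast clearance), compound 1 gives 22 mL.min-1.g-1, the only plain number among the two values shown. Compound 2 sits at the limit of < 10 mL.min-1.g-1 in this assay, at which 1 of the 2 values shown sits. Among the measured compounds shown here, the one measured step is an at least 2.2-fold lower number from compound 1 to compound 2 (0.34 log units; beyond the scatter), where 6-methyl-1H-indazol-5-yl replaced 4-hydroxy-2-methylphenyl on the amide-type nitrogen.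

Compound 3 `Cc1cc(CN2CC(C(=O)O)C2)ccc1NC(=O)c1cc(N(CC2CC2)C2CCCCC2)ncn1` differs from compound 1 by (3-carboxyazetidin-1-yl)methyl in place of hydroxy on an aromatic carbon. The measured step bears on this only loosely: it too removed the hydroxy group, but it also rebuilt the ring, so it gives a direction rather than a size. On that basis compound 3 is expected to show a lower number in this assay, a 1.8-fold lower number from compound 1 to compound 3 (0.26 log units; within the scatter), though with wide uncertainty. The estimate for compound 3 is 12 mL.min-1.g-1, with a range from 5 mL.min-1.g-1 to 30 mL.min-1.g-1.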

Compound 3, intrinsic clearance in microsomes: < 10 mL.min-1.g-1
Compound 3 was reported as a limit; the forecaster's own chance of this, stated with the estimate: 35%; middle value at least 1.2-fold (0.07 log units) away from the limit.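

In this assay, the step at this aromatic carbon, para to a large group, is an at least 2.2-fold lower number from compound 1 to compound 3 (0.34 log units; beyond the scatter). Compound 2 had lost the hydroxy group only with the ring itself rebuilt, whereas here the six-membered aromatic ring of carbon stays and the change falls on the group alone, so the lower number does not depend on rebuilding the ring. The much larger (3-carboxyazetidin-1-yl)methyl group is also tolerated at this place without any rise in the number, although the result for compound 3 is a limit and the step gives only a minimum size: the limit of < 10 mL.min-1.g-1 in this assay, at which 2 of the 3 values shown sit.

The compounds shown do not tell whether the carboxylic acid, the azetidine ring or simply the loss of the hydroxy group goes with the lower number. On these data alone, whether a plain amine or a longer chain at this carbon would read the same also remains open.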